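Two measured compounds and one open step

This account rests on a few compounds, and the source may have more. Where it says the series, first, only, none or still open, it means among the compounds named here.

Measured so far in a functional assay on MCF7 cells (Homo sapiens) for cytotoxicity, read by MTT assay, with a stated time of 48 h; on this read-out lower numbers stand for stronger inhibition and higher numbers for weaker inhibition
compound 1 `S=C(N/N=C\c1ccnc2ccccc12)Nc1cccnc1` gives 970 nM
compound 2 `O=[N+]([O-])c1ccc(NC(=S)N/N=C\c2ccnc3ccccc23)cc1` gives 810 nM

Compound 2 gives 810 nM as its number, and compound 1 gives 970 nM as its number. These two values lie within the usual scatter of each other, so neither stands apart. Compound 3 `S=C(N/N=C\c1ccnc2ccccc12)Nc1ccccc1` has not yet been measured. Its difference from compound 2 is hydrogen in place of nitro on an aromatic carbon in one place: hydrogen in place of nitro on an aromatic carbon, para to a large group. For the measured compounds named here, no measured step shows this change on its own. In this assay no step beyond the scatter is expected, and no direction can be favoured. The estimated 1.1-fold higher number from compound 2 to compound 3 (0.05 log units; within the scatter) is therefore expected to remain small. For compound 3 the estimate is 900 nM with an expected range from 350 nM to 2500 nM in this measurement.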

Compound 3, half-maximal inhibitory concentration: 1070 nM
Estimate against measurement, compound 3: 1.2-fold (0.08 log units) below; the range from low to high includes it.
By their numbers in this assay, from the lowest: compounds 2, 1 and 3 (each within the scatter of the next).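

In this assay, hydrogen in place of nitro on the aromatic carbon para to a large group gives a 1.3-fold higher number from compound 2 to compound 3 (0.12 log units; within the scatter), so at this position the nitro group can be absent without a step beyond the scatter. Phenyl in place of pyridin-3-yl on the amide-type nitrogen gives a 1.1-fold higher number from compound 1 to compound 3 (0.04 log units; within the scatter), and thus neither change separates the three compounds in this measurement. Nothing available bears on why these steps are so small.

On these data alone, it remains open whether an amine or a carboxylic acid at that same aromatic carbon would give a step beyond the scatter. Also open is whether a longer chain in place of phenyl on the amide-type nitrogen would do so, since the compounds shown carry only aromatic rings there.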